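This account rests on a few compounds, and the source may have more. Where it says the series, first, only, none or still open, it means among the compounds named here.

Two esters of one shared core have been measured, and a third awaits. Compound 1 `C=C1C(=O)O[C@H]2CC3=C[C@H](C/C(C)=C/[C@@H](OC(=O)c4ccc(C(F)(F)F)cc4)[C@H]12)OC3=O` carries a trifluoromethyl on its aromatic ring; compound 2 `C=C1C(=O)O[C@H]2CC3=C[C@H](C/C(C)=C/[C@@H](OC(=O)c4ccc(C(C)=O)cc4)[C@H]12)OC3=O` carries an acetyl there instead; compound 3 `C=C1C(=O)O[C@H]2CC3=C[C@H](C/C(C)=C/[C@@H](OC(=O)C4CC4)[C@H]12)OC3=O` replaces the whole aryl with a small ring. In a functional assay on NCI-H460 cells (Homo sapiens) for cytotoxicity, read by MTT assay, with a stated time of 48 h (on this read-out lower numbers stand for stronger inhibition and higher numbers for weaker inhibition), compound 1 gives > 10000 nM, which is a limit of the assay rather than a number. In this assay, within the data shown here, compound 2 gives 2200 nM, the only actual number so far. Among the measured compounds shown here, the single step, an at least 4.5-fold lower number from compound 1 to compound 2 (0.65 log units; beyond the scatter), therefore rests on one side on (the limit of > 10000 nM in this assay, at which 1 of the 2 values shown sits), so its true size is not known.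

The change now, (cyclopropyl in place of 4-acetylphenyl on a carbonyl carbon), is not of the same kind: it removes the 4-acetylphenyl altogether, so the measured step says little about it. For the measured compounds named here, with no step of this kind available, the expectation for compound 3 is broad and leans weaker, and the step that is estimated is a 2.3-fold higher number from compound 2 to compound 3 (0.36 log units; beyond the scatter). Compound 3 is thus expected to give about 5000 nM in this assay, within a range from 1500 nM to 20000 nM.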

Compound 3, half-maximal inhibitory concentration: 3000 nM
Compound 3: the middle estimate sits 1.7-fold (0.22 log units) above what was measured; measured number inside the range.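

The ester position, on a carbonyl carbon whose other neighbour is the oxygen, turns out not to need an aromatic ring to keep this level of activity: in this assay, swapping 4-acetylphenyl for the much smaller cyclopropyl gives a 1.4-fold higher number from compound 2 to compound 3 (0.13 log units; within the scatter), so compound 2 and compound 3 cannot be told apart here. In this assay compound 1 gives > 10000 nM, which is a limit of the assay and not a number. Cyclopropyl in place of 4-(trifluoromethyl)phenyl gives an at least 3.3-fold lower number from compound 1 to compound 3 (0.52 log units; beyond the scatter), so having an aryl ring at this position does not by itself set the activity, and the true size of this step stays unknown because one side of it is that limit: the limit of > 10000 nM in this assay, at which 1 of the 3 values shown sits.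

Going by these compounds, what remains open is whether any small group on this carbonyl would serve equally well, as a plain methyl, a cyclohexyl or a longer chain such as butyl would show. It is also open how a group bearing an amine or a carboxylic acid would behave at this position, and no group shown here reaches a clearly stronger value than compound 2.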